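The source may hold more compounds than are shown below. What is called first, only, known or untested is meant among the compounds shown, and "the series" means these compounds.

A set of compounds was tested in an ADME assay for permeability, using PAMPA, at pH 5.5; a lower number here means that the compound crosses the layer more slowly, a higher number that the compound crosses the layer faster. Compound 1, `CC(C)COc1ncc(-c2cn(C)c3cc(C(=O)NS(C)(=O)=O)ccc23)cc1Cl`, and compound 2, `CC(C)COc1ncc(-c2cn(C)c3cc(C(=O)NS(C)(=O)=O)c(F)cc23)cc1Cl`, share a core and differ only at one aromatic carbon. In this assay compound 1 gives 443 nm/s, and compound 2 gives 495 nm/s. The change from compound 2 to compound 1 is hydrogen in place of fluoro on an aromatic carbon, and it made the step of a 1.1-fold lower number from compound 2 to compound 1 (0.05 log units; within the scatter).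

Compound 3, `Cn1cc(-c2ccc(C(F)(F)F)cc2)c2cc(F)c(C(=O)NS(C)(=O)=O)cc21`, carries a different core; how the two cores differ is not broken down here. In this assay compound 3 gives 712 nm/s, a number that stands within the scatter of both compound 1 and compound 2.

Compound 4, `Cn1cc(-c2ccc(C(F)(F)F)cc2)c2ccc(C(=O)NS(C)(=O)=O)cc21`, has not yet been measured. It is made from compound 3 by the change (hydrogen in place of fluoro on an aromatic carbon), the same change that turned compound 2 into compound 1, at a place described in the same words. Since that change made the step of a 1.1-fold lower number from compound 2 to compound 1 (0.05 log units; within the scatter), a step of the same size is expected on the new core. The expected step of a 1.1-fold lower number from compound 3 to compound 4 (0.04 log units; within the scatter) rests on that earlier step alone. Compound 4 is therefore expected to give about 650 nm/s in this assay. Its value is expected to fall between 400 nm/s and 1000 nm/s, given that the earlier step lay within the scatter.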

Compound 4, apparent permeability: 972 nm/s
The estimate for compound 4 lay 1.5-fold (0.17 log units) below the measured number; the measured number falls inside the stated range.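

Putting hydrogen in place of fluoro on the aromatic carbon ortho to the (methylsulfonyl)carbamoyl group gives, in this assay, a 1.4-fold higher number from compound 3 to compound 4 (0.14 log units; within the scatter), so on this second core the step again stays inside the spread that repeated measurements would show. Set side by side, the two steps cannot be told apart: the same change on two cores in this assay, a 1.1-fold lower number (0.05 log units; within the scatter) from compound 2 to compound 1 and a 1.4-fold higher number (0.14 log units; within the scatter) from compound 3 to compound 4, 1.5-fold (0.18 log units) apart, within the scatter of two such steps. This shows that, across these two pairs, the change carries from one core to the other as a step too small to read, but it does not show a real effect of the change on either core, and the opposite directions of the two steps carry no meaning, nor does it show that the same would hold on a third core.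

Hydrogen and fluoro are the only groups shown at this aromatic carbon, which leaves open whether a methoxy group or a nitrile there would give a step beyond the scatter. All four compounds also keep the (methylsulfonyl)carbamoyl group, so how the same change behaves when a carboxylic acid stands in its place remains an open question.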